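Removing the ring methyl from compound 1

A few compounds are considered here, and "the series" means these few. Any claim that something is new, unique, unknown or untested is made for them only; others in the source may bear on it.

Going by the values given here, compound 1 `CC(=O)N1CCC(C(=O)Nc2sc3c(c2C(=O)NC2CC2)CCC(C)C3)CC1` gives, in an assay for displacement of a labelled ligand from DNA repair protein REV1 (Homo sapiens), read by fluorescence polarization, with a stated time of 1 h (on this read-out higher numbers stand for weaker binding and lower numbers for tighter binding), 4400 nM, the lower of the two numbers so far; the nearest is compound 2 `CC(=O)N1CCC(C(=O)Nc2sc3c(c2C(N)=O)CCC(C)C3)CC1` with 12600 nM. Compound 3 `CC(=O)N1CCC(C(=O)Nc2sc3c(c2C(=O)NC2CC2)CCCC3)CC1` differs from compound 1 by hydrogen in place of methyl on a saturated ring carbon. Among the compounds with values here, the single step measured so far, a 2.9-fold higher number from compound 1 to compound 2 (0.46 log units; beyond the scatter), concerns the amide-type nitrogen and not the saturated ring, so it does not bear on this change; no measured step does. For this assay the expectation is a change no larger than the scatter, about a 1.4-fold higher number from compound 1 to compound 3 (0.13 log units; within the scatter). Compound 3 is therefore estimated at 6000 nM, in the range 2500 nM to 15000 nM.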

Compound 3, dissociation constant: 26600 nM
Compound 3: middle estimate off by 4.4-fold (0.65 log units), on the low side; measured number outside the range, above it.
By their numbers in this assay, from the lowest: compound 1; then compound 2; then compound 3.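

The methyl on the saturated ring carbon matters in this series: hydrogen in its place gives a 6.0-fold higher number from compound 1 to compound 3 (0.78 log units; beyond the scatter). The saturated ring is therefore a second place, besides the amide-type nitrogen, where a one-carbon change moves the number beyond the scatter.

From the compounds shown here alone, whether an ethyl, a longer chain or a hydroxyl on the same ring carbon would give a lower number than compound 1 remains open, as does whether the methyl counts equally with hydrogen in place of cyclopropyl on the amide-type nitrogen. No data at hand offer a reason for this step.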